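This account rests on a few compounds, and the source may have more. Where it says the series, first, only, none or still open, it means among the compounds named here.

Working notes on the series.

In an assay on isolated protein for inhibition of 11-beta-hydroxysteroid dehydrogenase type 2 (Homo sapiens) (a higher number here means a weaker inhibitor, a lower number a stronger inhibitor), compound 1 `Cn1c(-c2ccc(-c3cncnc3)cc2)nnc1C1(c2ccc(Cl)cc2)CCC1` reaches only the limit of the measurement, > 4000 nM. Compound 2 `Cn1c(-c2ccc(C(=O)NC3CC3)cc2)nnc1C1(c2ccc(Cl)cc2)CCC1` likewise sits at the limit, > 4000 nM, in this assay. Compound 3 `Cn1c(-c2ccc(-c3cccnc3)cc2Cl)nnc1C1(c2ccc(Cl)cc2)CCC1` also gives only the limit, > 4000 nM. The step that the two limits leave unreadable from compound 1 to compound 2, cyclopropylcarbamoyl in place of pyrimidin-5-yl on an aromatic carbon, is unreadable because both of its ends rest at the limit of > 4000 nM in this assay, at which 3 of the 3 values shown sit. For the measured compounds named here, compound 2 thus stands at the limit on every number so far, and nothing among the measured compounds separates it from the others.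

Compound 4 `CCNC(=O)c1ccc(-c2nnc(C3(c4ccc(Cl)cc4)CCC3)n2C)cc1` differs from compound 2 by ethyl in place of cyclopropyl on an amide-type nitrogen, which read one bond further out is cyclopropylcarbamoyl to ethylcarbamoyl. Going by the values given here, no measured step touches this amide nitrogen. Among the compounds with values here, the only measured step, from compound 1 to compound 2, is itself unreadable, and all three values shown sit at the limit of > 4000 nM in this assay, at which 3 of the 3 values shown sit. No step beyond the scatter is therefore expected in this assay, and the step that the limit leaves unreadable from compound 2 to compound 4 is expected to be within the scatter. For compound 4 the estimate in this assay is 8000 nM, with a range of 3000 nM to 30000 nM, and most likely the measurement will again be reported as a limit only.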

Compound 4, half-maximal inhibitory concentration: > 4000 nM
Compound 4: no number, only a limit; the forecaster's own chance of this, stated with the estimate: 85%; the middle value is on the limit's open side.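

In this assay compound 4 also gives only a limit, > 4000 nM. The steps from compound 2 and from compound 1 to compound 4 therefore cannot be read: the limit of > 4000 nM in this assay, at which 4 of the 4 values shown sit.

The compounds shown leave open what the actual values in this assay are, and whether compound 1, compound 2 and compound 4 differ at all.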